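Swapping Ethyl for Fluoro on the Aryl Ring

The source may report more compounds than this note shows. Statements on the series, on what has been measured and on what is new or still open speak of the compounds shown alone.

Measured so far in a functional assay on the whole organism (strain Wistar) for inhibition, with Rattus norvegicus as the target, read by paw edema, with stated times of 30 min and 5 h, at a dose of 0.05 mmol/kg by the oral route; a higher number here means more inhibition at the dose given (going by the name of the read-out), a lower number less inhibition:
compound 1, `Cc1cc(O)ccc1C1=NN(c2ccc(S(C)(=O)=O)cc2)C(=O)CC1`, gives 52.6%
compound 2, `CCc1ccc(C2=NN(c3ccc(S(C)(=O)=O)cc3)C(=O)CC2)cc1`, gives 65.7%
compound 3, `COc1ccc(C2=NN(c3ccc(S(C)(=O)=O)cc3)C(=O)CC2)cc1OC`, gives 82.4%

Compound 2 stands second of the three in this assay. Among the measured compounds shown here, the only measured step, a number 13.1 percentage points higher from compound 1 to compound 2 (beyond the scatter), is modest but beyond the scatter. Compound 3 sits higher than compound 2, and that gap is also beyond the scatter, but the two differ in more than one place, so no single change can be read from it.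

Compound 4, `CS(=O)(=O)c1ccc(N2N=C(c3ccc(F)cc3)CCC2=O)cc1`, is not yet measured. Its change from compound 2 is fluoro in place of ethyl on an aromatic carbon. For the measured compounds named here, no measured step touches this particular change: the step from compound 1 to compound 2 altered a different group at a different spot, and compound 3 differs by two groups at once. There is therefore nothing to argue for a movement beyond the scatter in either direction, and the expected step of a number 3.7 percentage points lower from compound 2 to compound 4 (within the scatter) is small. Compound 4 is estimated to give 62%, within 45% to 78%.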

Compound 4, a percentage reported as inhibition, in the whole organism at one dose (the size of the read-out at that dose, not a potency): 73.6%
Compound 4: middle estimate off by 11.6 percentage points, on the low side, within the range that was stated.
By their numbers in this assay, from the lowest: compound 1; then compounds 2, 4 and 3 (each within the scatter of the next, the first and the last beyond it).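

In this assay, the step of a number 7.9 percentage points higher from compound 2 to compound 4 (within the scatter) shows that ethyl and fluoro, on an aromatic carbon para to a large group, cannot be told apart at this dose, even though the entering group has fewer heavy atoms than the one it replaces. The step of a number 21 percentage points higher from compound 1 to compound 4 (beyond the scatter) places compound 4 clear of compound 1, so the 4-fluorophenyl version, like the 4-ethylphenyl one, stands apart from the 4-hydroxy-2-methylphenyl one. No measurement is available to explain these results.

From the compounds shown here alone, whether an amine, a carboxylic acid or a longer chain such as butyl at the same place would keep this level of inhibition stays open. A single dose also leaves open whether compound 2 and compound 4 would separate at other doses.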